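Amine substitution on the shared core: step to compound 4

This account rests on a few compounds, and the source may have more. Where it says the series, first, only, none or still open, it means among the compounds named here.

Measured compounds:
compound 1 `CCCCc1ccc(CNS(=O)(=O)c2ccccc2)c(=O)n1Cc1ccc(-c2ccccc2-c2nn[nH]n2)cc1`: 25.2%
compound 2 `CCCCc1ccc(CNC(=O)N(C)C)c(=O)n1Cc1ccc(-c2ccccc2-c2nn[nH]n2)cc1`: 28%
compound 3 `CCCCc1ccc(CN)c(=O)n1Cc1ccc(-c2ccccc2-c2nn[nH]n2)cc1`: 2.8%

All three share one core and differ only at the amine nitrogen. In a functional assay on the whole organism (artery) for inhibition, with Rattus norvegicus as the target, at a dose of 3 mg/kg by the intraduodenal route (a higher number here means more inhibition at the dose given (going by the name of the read-out), a lower number less inhibition), compound 1 gives 25.2% and compound 2 gives 28%; these two lie within the scatter of each other, as a number 2.8 percentage points higher from compound 1 to compound 2 (within the scatter) shows. Compound 3, the free amine, gives 2.8% and stands lowest of the three, beyond the scatter from both others.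

Compound 4 `CCCCc1ccc(CNC(=O)Nc2ccccc2)c(=O)n1Cc1ccc(-c2ccccc2-c2nn[nH]n2)cc1` is not yet measured. It differs from compound 3 by phenylcarbamoyl in place of hydrogen on an amine nitrogen. For the measured compounds named here, two measured steps bear on this: removing a group from that nitrogen gave a number 22.4 percentage points lower from compound 1 to compound 3 (beyond the scatter) and a number 25.2 percentage points lower from compound 2 to compound 3 (beyond the scatter), both modest and beyond the scatter. Putting a phenylcarbamoyl group onto the same nitrogen is the reverse kind of change, so a rise of similar size is expected, a number 23.2 percentage points higher from compound 3 to compound 4 (beyond the scatter). Compound 4 is therefore estimated at 26%, with a range from 12% to 40%.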

Compound 4, a percentage reported as inhibition, in the whole organism at one dose (the size of the read-out at that dose, not a potency): 0%
Compound 4: middle estimate off by 26 percentage points, on the high side; measured number outside the range, below it.
By their numbers in this assay, from the lowest: compounds 4 and 3 (each within the scatter of the next); then compounds 1 and 2 (each within the scatter of the next).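

In this assay a group on the amine nitrogen is not enough on its own: a number 2.8 percentage points lower from compound 3 to compound 4 (within the scatter) after phenylcarbamoyl enters, which breaks the pattern of compound 1 and compound 2 standing above the free amine. What the group carries matters, since a number 28 percentage points lower from compound 2 to compound 4 (beyond the scatter) with anilino in place of dimethylamino on a carbonyl carbon, and a number 25.2 percentage points lower from compound 1 to compound 4 (beyond the scatter) with phenylcarbamoyl in place of phenylsulfonyl. No supporting data bear on why this change behaves as it does.

Open, as far as these compounds go, is whether methylamino on the same carbonyl carbon, or an acetyl group on the amine nitrogen, would read with compound 2 or with compound 4. Also open, from the compounds shown here alone, is how these compounds compare at other doses, since the read-out comes from a single dose.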